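The compounds below may be only part of what the source reports. "The series", "measured", "known", "first", "only" and "open" are said of these compounds alone.

Working notes on the series. Compound 1 `N#Cc1ccn2c(-c3ccccc3)c(-c3ccccc3)c(C(O)C3CCCCC3)c2c1` carries a cyclohexyl(hydroxy)methyl group on the shared core; in an assay for inhibition of Polyunsaturated fatty acid lipoxygenase ALOX15 (Oryctolagus cuniculus) (a higher number here means a weaker inhibitor, a lower number a stronger inhibitor), compound 1 has "not determined" (no result reported), so no number places it. The neighbours on the same core give the only anchors: compound 2 `N#Cc1ccn2c(-c3ccccc3)c(-c3ccccc3)c(CO)c2c1` gives 34000 nM, and compound 3 `N#Cc1ccn2c(-c3ccccc3)c(-c3ccccc3)c(C(=O)c3ccccc3)c2c1` gives 43000 nM; the step of a 1.3-fold higher number from compound 2 to compound 3 (0.10 log units; within the scatter) shows that exchanging groups at this position left the read-out essentially where it was. Compound 4 `N#Cc1ccn2c(-c3ccccc3)c(-c3ccccc3)c(C(O)c3ccccc3)c2c1` differs from compound 1 by phenyl in place of cyclohexyl on a saturated chain carbon bound to an aromatic carbon and an oxygen on a saturated carbon. For the measured compounds named here, no measured step bears directly on this exchange, and compound 1 itself has no number, so the expectation rests on compounds 2 and 3 alone. Compound 4 is expected to fall near them, at about 38000 nM (range 12000 nM to 110000 nM).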

Compound 4, half-maximal inhibitory concentration: 48000 nM
Beside the measured number, compound 4's estimate is 1.3-fold (0.10 log units) below it, and the stated range covers the measured number.
By their numbers in this assay, from the lowest: compounds 2, 3 and 4 (each within the scatter of the next).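

In this assay the change from benzoyl to hydroxy(phenyl)methyl gives a 1.1-fold higher number from compound 3 to compound 4 (0.05 log units; within the scatter) and the addition of phenyl to the saturated chain carbon gives a 1.4-fold higher number from compound 2 to compound 4 (0.15 log units; within the scatter) at this position. Neither exchanging the carbonyl for a hydroxy-bearing carbon nor adding phenyl there moves the read-out beyond the scatter in these compounds. Nothing at hand accounts for this result.

Compound 1 gives "not determined" (no result reported) here and the exchange of cyclohexyl for phenyl cannot be read. Going by these compounds, whether an amine or a carboxylic acid at this position would shift the read-out remains open.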